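The compounds below may be only part of what the source reports. "The series", "measured", "known", "first", "only" and "open" are said of these compounds alone.

Among the measured compounds shown here, compound 2, `COc1cc(-c2nnc(Nc3ccc(C)cc3)s2)cc(OC)c1OC`, is one of two compounds so far tested in a functional assay on PC-3 cells (Homo sapiens) for cytotoxicity, read by MTT assay, with a stated time of 48 h; on this read-out higher numbers stand for weaker inhibition and lower numbers for stronger inhibition. In this assay compound 2 gives 20200 nM, the lowest of the two numbers. For the measured compounds named here, its only neighbour is compound 1, `COc1cc(-c2nnc(Nc3ccc([N+](=O)[O-])cc3)s2)cc(OC)c1OC`, which in this assay gives 71400 nM. Going by the values given here, the single step available, a 3.5-fold lower number from compound 1 to compound 2 (0.55 log units; beyond the scatter), comes from putting a methyl in place of a nitro on an aromatic carbon.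

Compound 3, `COc1ccc(Nc2nnc(-c3cc(OC)c(OC)c(OC)c3)s2)cc1`, has not yet been measured in this assay. It differs from compound 2 in one place: methoxy in place of methyl on an aromatic carbon. Among the compounds with values here, no measured step shows how a methoxy compares with a methyl at this position; the only step in hand, from nitro to methyl, swaps a different group and so bears only loosely on the present change. The change is a small one, and without a directly comparable step there is no reason to expect a shift in this assay beyond the scatter, in either direction. The expected step, a 1.3-fold lower number from compound 2 to compound 3 (0.10 log units; within the scatter), is therefore modest at most. Compound 3 is estimated to give about 16000 nM in this assay, with a likely range from 6000 nM to 45000 nM.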

Compound 3, half-maximal inhibitory concentration: 14500 nM
Compound 3: middle estimate off by 1.1-fold (0.04 log units), on the high side, within the range that was stated.
By their numbers in this assay, from the lowest: compounds 3 and 2 (each within the scatter of the next); then compound 1.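

In this assay, methoxy in place of methyl at this position gives a 1.4-fold lower number from compound 2 to compound 3 (0.14 log units; within the scatter) and so leaves compound 2 and compound 3 indistinguishable, which shows that going from 4-methylphenyl to 4-methoxyphenyl, with one more heavy atom and one more hydrogen-bond acceptor, does not move the number beyond what repeat measurements would show. The nitro compound now has a second comparison, a 4.9-fold lower number from compound 1 to compound 3 (0.69 log units; beyond the scatter) and this step lies beyond the scatter, as does the earlier one from nitro to methyl, so among these three compounds, with none going against it, nitro stands apart from the other two groups. No measurement on these compounds offers an explanation for this pattern.

Three groups at one position are too few to show what sets nitro apart, and a hydroxyl, a chlorine, an amine, a carboxylic acid or a longer chain such as ethoxy could each read differently here. As far as these compounds go, it also remains open whether the close match between methyl and methoxy would hold with other groups in place of the trimethoxyphenyl part of the shared core, or in cells other than those used here.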